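This account rests on a few compounds, and the source may have more. Where it says the series, first, only, none or still open, it means among the compounds named here.

Measured compounds:
Compound 1, `O=C(O)CCn1cc(Cc2ccc(F)cc2)c2cc(NS(=O)(=O)c3ccc(F)cc3)ccc21`, 0.479 nM
Compound 2, `Cc1ccc(S(=O)(=O)Nc2ccc3c(c2)c(Cc2ccc(F)cc2)cn3CCC(=O)O)cc1`, 0.269 nM
Compound 3, `O=C(O)CCn1cc(Cc2ccc(F)cc2)c2cc(NS(=O)(=O)c3ccccc3)ccc21`, 0.676 nM

These three compounds share one core and differ only in the group on the ring attached to the sulfonyl. In a functional assay on aorta for antagonist activity at thromboxane A2 receptor (Rattus norvegicus) (a higher number here means weaker binding, a lower number tighter binding), compound 3 gives the highest of the three numbers: its nearest neighbour is compound 1, with a 1.4-fold higher number from compound 1 to compound 3 (0.15 log units; within the scatter), and the further one is compound 2, with a 2.5-fold higher number from compound 2 to compound 3 (0.40 log units; beyond the scatter).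

Compound 4, `COc1ccc(S(=O)(=O)Nc2ccc3c(c2)c(Cc2ccc(F)cc2)cn3CCC(=O)O)cc1`, is reached from compound 3 by one change: methoxy in place of hydrogen on an aromatic carbon. Within the data shown here, two measured steps bear on this. Putting methyl at that spot, read in the direction from compound 2 to compound 3, moved the number modestly; putting fluoro there, read from compound 1 to compound 3, stayed within the scatter. A methoxy at the same spot is therefore expected to give a small decrease in the number, or none beyond the scatter, as a 1.5-fold lower number from compound 3 to compound 4 (0.18 log units; within the scatter). For compound 4 the expected value in this assay is 0.45 nM, between 0.2 nM and 1 nM.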

Compound 4, dissociation constant: 0.174 nM
The estimate for compound 4 lay 2.6-fold (0.41 log units) above the measured number, outside the stated range (below it).
By their numbers in this assay, from the lowest: compounds 4, 2, 1 and 3 (each within the scatter of the next, the first and the last beyond it).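

Replacing phenyl with 4-methoxyphenyl gives a 3.9-fold lower number from compound 3 to compound 4 (0.59 log units; beyond the scatter) and is the largest step seen so far at this position, para to a large group. Methoxy in place of fluoro also gives a step beyond the scatter, a 2.8-fold lower number from compound 1 to compound 4 (0.44 log units; beyond the scatter) in this series, whereas methoxy in place of methyl gives a 1.5-fold lower number from compound 2 to compound 4 (0.19 log units; within the scatter) and so cannot be separated from it. Compared with hydrogen, methoxy and methyl both lower the number beyond the scatter, while fluoro does not, so a substituent here does not lower the number by its presence alone.

No supporting evidence accounts for this difference among the groups. On these data alone, it remains open how a longer chain such as ethoxy, or an amine or hydroxyl at the same spot, would compare with methoxy.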